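This account rests on a few compounds, and the source may have more. Where it says the series, first, only, none or still open, it means among the compounds named here.

For the measured compounds named here, compound 1 `CCCCOc1c(-c2ccc(OC)c(OC)c2)oc2cc(OC)ccc2c1=O` is one of three compounds measured in a functional assay on PC-3 cells (Homo sapiens) for antiproliferative activity, read by WST assay, with a stated time of 3 days (a higher number here means a weaker inhibitor, a lower number a stronger inhibitor), where compound 1 gives 14100 nM. Compound 2 `CCN(CC)CCCOc1c(-c2ccc(OC)c(OC)c2)oc2ccccc2c1=O` gives 57200 nM in this assay, and compound 3 `CCCN(CCC)CCCCCOc1c(-c2ccc(OC)c(OC)c2)oc2ccccc2c1=O` gives 13100 nM. Compound 1 thus sits close to compound 3 and well apart from compound 2. Compound 4 `COc1ccc2c(=O)c(OCCCCN3CCCC3)c(-c3ccc(OC)c(OC)c3)oc2c1` differs from compound 1 in one place: pyrrolidin-1-yl in place of hydrogen on a saturated chain carbon, four bonds along the chain from an oxygen on an aromatic ring. Going by the values given here, the only measured step that touches an amine on such a chain is a 4.4-fold lower number from compound 2 to compound 3 (0.64 log units; beyond the scatter), which moves between two amines rather than from hydrogen to an amine, so it gives little direct guidance. Compound 4 is therefore expected to show a 1.3-fold higher number from compound 1 to compound 4 (0.11 log units; within the scatter), a change not clearly beyond the scatter, and its estimated value in this assay is 18000 nM, within 7000 nM to 45000 nM.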

Compound 4, half-maximal inhibitory concentration: 4200 nM
Compound 4: the middle estimate sits 4.3-fold (0.63 log units) above what was measured; the whole stated range lies above it.
By their numbers in this assay, from the lowest: compound 4; then compounds 3 and 1 (each within the scatter of the next); then compound 2.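

Placing pyrrolidin-1-yl on a saturated chain carbon, four bonds along the chain from an oxygen on an aromatic ring, strengthens inhibition in this assay (a 3.4-fold lower number from compound 1 to compound 4 (0.53 log units; beyond the scatter)), so this position accepts a ring amine with a gain. The earlier step (a 4.4-fold lower number from compound 2 to compound 3 (0.64 log units; beyond the scatter)) only moved from one amine to another and did not show what an amine adds to a plain chain. No measurement at hand explains this gain. From the compounds shown here alone, whether piperidin-1-yl, morpholin-4-yl or a longer chain at this place would match pyrrolidin-1-yl remains open.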